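Triazole series: compound 2 to compound 4 in this assay

A few compounds are considered here, and "the series" means these few. Any claim that something is new, unique, unknown or untested is made for them only; others in the source may bear on it.

Compound 2 `CC(C)NC(=O)CC(c1ccc(-c2ccc3cccc(F)c3c2)[nH]c1=O)C(C)C` stands second highest of the three numbers in an ADME assay on microsomes from liver (Homo sapiens) for metabolic stability (a lower number here means that the compound disappears faster, a higher number that the compound lasts longer), giving 0.32 h. Compound 3 `Cc1nc(C(c2ccc(-c3ccc4cccc(F)c4c3)[nH]c2=O)C(C)C)[nH]c1C` gives 0.268 h, and the difference a 1.2-fold lower number from compound 2 to compound 3 (0.08 log units; within the scatter) lies within the scatter, so no order is claimed. Compound 1 `CC(C)C(c1nnc[nH]1)c1ccc(-c2ccc3cccc(F)c3c2)[nH]c1=O` gives 0.905 h, the highest of the three.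

Compound 4 `CC(C)C(Nc1nnc[nH]1)c1ccc(-c2ccc3cccc(F)c3c2)[nH]c1=O` differs from compound 2 in one place: (4H-1,2,4-triazol-3-yl)amino in place of (isopropylcarbamoyl)methyl on a saturated chain carbon bound to an aromatic carbon and a saturated chain carbon. The step that bears most on it is a 2.8-fold lower number from compound 1 to compound 2 (0.45 log units; beyond the scatter), since compound 4 brings a triazole ring back onto that chain carbon, now through an amino link; a 3.4-fold lower number from compound 1 to compound 3 (0.53 log units; beyond the scatter) shows another ring giving a lower number. A rise of a 1.9-fold higher number from compound 2 to compound 4 (0.27 log units; within the scatter) is therefore expected, short of compound 1.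

Compound 4 is estimated at 0.6 h, with a range from 0.3 h to 1.2 h.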

Compound 4, half-life: > 3 h
Compound 4 gave a limit, no number; the forecaster's own chance of this, stated with the estimate: 5%; at least 5.0-fold (0.69 log units) between middle value and limit.
By their numbers in this assay, from the lowest: compounds 3 and 2 (each within the scatter of the next); then compound 1. At a limit, above all of these: compound 4.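

In this assay compound 4 gives > 3 h, a limit of the assay and not a number. At this saturated chain carbon, (4H-1,2,4-triazol-3-yl)amino gives an at least 9.3-fold higher number from compound 2 to compound 4 (0.97 log units; beyond the scatter) and an at least 11-fold higher number from compound 3 to compound 4 (1.04 log units; beyond the scatter) and, against the same ring without the amino link, an at least 3.3-fold higher number from compound 1 to compound 4 (0.52 log units; beyond the scatter). How far these steps reach cannot be read: the limit of > 3 h in this assay, at which 1 of the 4 values shown sits.

As far as these compounds go, whether the ring is needed at all stays open, since a plain amine on this chain carbon would test the amino link alone. A methylene link to the same triazole ring would test whether the nitrogen of that link matters.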